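Swapping the Aryl Group on the Triazole Arm

This account rests on a few compounds, and the source may have more. Where it says the series, first, only, none or still open, it means among the compounds named here.

Compound 3 `COc1ccc(-n2nncc2CN2C(=O)C3(C(C#N)=C(N)Oc4c3c3nc5ccccc5nc3c3ccccc43)c3ccccc32)cc1` was run in a functional assay on HCT-116 cells (Homo sapiens) for antiproliferative activity, read by MTT assay, with a stated time of 48 h; on this read-out lower numbers stand for stronger inhibition and higher numbers for weaker inhibition. In this assay compound 3 gives only a limit, > 50000 nM. Its two near relatives stand no differently. Compound 1 `N#CC1=C(N)Oc2c(c3nc4ccccc4nc3c3ccccc23)C12C(=O)N(Cc1cnnn1-c1ccc(Cl)cc1)c1ccccc12` returns a limit too, > 50000 nM. Compound 2 `N#CC1=C(N)Oc2c(c3nc4ccccc4nc3c3ccccc23)C12C(=O)N(Cc1cnnn1-c1cccc(Br)c1)c1ccccc12` returns a limit as well, > 50000 nM. Compound 3 therefore stands level with both, at the limit shared by all three values (the limit of > 50000 nM in this assay, at which 3 of the 3 values shown sit). The steps among them cannot be read: a step that the two limits leave unreadable from compound 1 to compound 2, a step that the two limits leave unreadable from compound 1 to compound 3 and a step that the two limits leave unreadable from compound 2 to compound 3 all fall between two limits.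

Compound 4 `Cc1ccc(-n2nncc2CN2C(=O)C3(C(C#N)=C(N)Oc4c3c3nc5ccccc5nc3c3ccccc43)c3ccccc32)cc1C` differs from compound 3 in one place: 3,4-dimethylphenyl in place of 4-methoxyphenyl on an aromatic nitrogen. The three measured steps bear directly on this change, since each of them also exchanges the group on the same aromatic nitrogen, and none has a readable size. Three such exchanges left the read-out at the limit. Nothing here suggests that a fourth will move it. The expected step in this assay is a step that the limit leaves unreadable from compound 3 to compound 4, none beyond the scatter. The most likely outcome is that the assay again reports only a limit. Compound 4 is estimated at 60000 nM, within 20000 nM to 200000 nM.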

Compound 4, half-maximal inhibitory concentration: > 50000 nM
Compound 4: only a limit was reported; the forecaster's own chance of this, stated with the estimate: 85%; the middle value does not contradict the limit.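

For the compounds shown here, compound 4 also returns only a limit in this assay, > 50000 nM, so no step linking it to compound 1, compound 2 or compound 3 can be read. All four compounds stand together: the limit of > 50000 nM in this assay, at which 4 of the 4 values shown sit. The compounds shown leave open whether any group on this aromatic nitrogen can give a measurable value, and how the four groups rank.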